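Indoleamine 2,3-dioxygenase 1 series: carboxy to bromo step

The compounds below may be only part of what the source reports. "The series", "measured", "known", "first", "only" and "open" are said of these compounds alone.

Measured so far in an assay for inhibition of Indoleamine 2,3-dioxygenase 1 (Homo sapiens), with stated times of 10 min and 60 min, tested at 10 uM; on this read-out lower numbers stand for a weaker effect and higher numbers for a stronger effect at the one concentration tested:
compound 1, `O=[N+]([O-])c1ccc2[nH]c(CNc3cc(C(F)(F)F)cc4[nH]ncc34)cc2c1`, gives 22%
compound 2, `O=C(O)c1cccc(CNc2cc(C(F)(F)F)cc3[nH]ncc23)c1`, gives 11%

Compound 2 holds the lowest of the two numbers in this assay; the nearest is compound 1, which sits higher by a gap beyond the usual scatter. Among the compounds with values here, no pair of measured compounds differs in a single place, so no measured step is available as a guide.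

Compound 3, `FC(F)(F)c1cc(NCc2cccc(Br)c2)c2cn[nH]c2c1`, is not yet measured. It differs from compound 2 in one place: bromo in place of carboxy on an aromatic carbon. The measured compounds give no indication of how an exchange at this position behaves, so the estimated step of a number 4 percentage points higher from compound 2 to compound 3 (within the scatter) is expected to be small and of uncertain direction, most likely within the scatter. Compound 3 is estimated at 15%, with an expected range from 0% to 35%.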

Compound 3, a percentage reported as inhibition, at one concentration (the size of the read-out at that concentration, not a potency): 23%
Compound 3: the middle estimate sits 8 percentage points below what was measured; the measured number falls inside the stated range.
By their numbers in this assay, from the lowest: compound 2; then compounds 1 and 3 (each within the scatter of the next).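

In this assay the exchange of carboxy for bromo on this aromatic carbon gives the series its first step that can be read in one place: a number 12 percentage points higher from compound 2 to compound 3 (beyond the scatter) and counts as modest. The read-out at this position therefore responds to the group it carries, and it does not fall when the carboxy, with its hydrogen-bond donor and acceptor, gives way to a single bromine atom. Nothing at hand explains this step, so it stands as an observation on this one pair.

A single exchange cannot show whether the gain belongs to bromo itself or simply to the loss of carboxy, and a chloro, methoxy or amine group on the same carbon would separate the two. The read-out is also taken at one concentration, so the step says nothing about potency.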